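Replacing One Amide Group on Compound 1

This account rests on a few compounds, and the source may have more. Where it says the series, first, only, none or still open, it means among the compounds named here.

Among the measured compounds shown here, in a physicochemical assay for lipophilicity, at pH 7.4 (on this read-out higher numbers stand for higher lipophilicity and lower numbers for lower lipophilicity), compound 1 (`O=C(Nc1ccc2[nH]ccc2n1)[C@H]1CCCN1C(=O)C1(c2cccc(Cl)c2)CCCC1`) gives 5.9, the higher of the two numbers measured so far. Compound 2 (`O=C(Nc1ccc2[nH]ncc2n1)[C@H]1COCCN1C(=O)C1(c2ccc(Cl)cc2)CC(F)(F)C1`) gives 4.5, a gap beyond the usual scatter of repeated measurements. These two compounds differ in more than one place, so their gap cannot be tied to any single change.

Compound 3 (`CNC(=O)c1cccc(NC(=O)[C@H]2CCCN2C(=O)C2(c3cccc(Cl)c3)CCCC2)c1`) is not yet measured and differs from compound 1 in one place, on an amide-type nitrogen: a group of 10 heavy atoms (8 carbon, 1 nitrogen, 1 oxygen; one six-membered aromatic ring of carbon only) in place of a group of 9 heavy atoms (7 carbon, 2 nitrogen; one five-membered aromatic ring with 1 hetero atom, one six-membered aromatic ring with 1 hetero atom), on an amide-type nitrogen. The group that enters is 3-(methylcarbamoyl)phenyl, which has one six-membered aromatic ring of carbon only.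

For the measured compounds named here, no measured pair differs by one change alone, so the data give no direct guide to the size of this step, and any forecast is a judgement. Going by the values given here, the only hint is that compound 2 reaches 4.5, which shows that a related structure can sit well under compound 1. A moderate downward step is expected, estimated as a number 0.60 log units lower from compound 1 to compound 3 (beyond the scatter). In this assay, the estimated value for compound 3 is 5.3, with an expected range of 4.6 to 6.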

Compound 3, distribution coefficient: 5.5
Estimate against measurement, compound 3: 0.20 log units below; the range from low to high includes it.
By their numbers in this assay, from the lowest: compound 2; then compound 3; then compound 1.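

Among the compounds shown here, compound 1 and compound 3 differ only in the group on the amide-type nitrogen, so this pair gives the first reading that can be tied to a single place in the structure. In this assay, exchanging the group of two aromatic rings for 3-(methylcarbamoyl)phenyl gives a number 0.40 log units lower from compound 1 to compound 3 (beyond the scatter), so this position does affect the read-out, and a rather different group shifts it only modestly. The two groups have equal counts of hydrogen-bond donors and acceptors, and neither carries a net charge, so those counts do not separate them, and no measurement is available that explains the step.

Still open, going by these compounds, is whether the step follows from the change of ring or from the methylcarbamoyl group that the new ring carries; a plain phenyl on this nitrogen, or a phenyl bearing a carboxylic acid, would help to separate the two. Also open, on these data alone, is whether the same exchange would give a step of similar size on the core of compound 2, which differs from compound 1 in several other places.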